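Ester series on the shared core: pyridinyl ester to glycinate

The source may hold more compounds than are shown below. What is called first, only, known or untested is meant among the compounds shown, and "the series" means these compounds.

Two esters and one related amide of the shared core are in hand. For the measured compounds named here, compound 1 `C=C1CC[C@H]2[C@@](C)(CCC(=O)N[C@@]2(C)CO)[C@@H]1/C=C/C1=CCOC1=O`, in which the ring carries a lactam, is the first. In an assay for inhibition of hexokinase-2 (Homo sapiens), read by coupled enzyme assay, with a stated time of 10 min, in the presence of a further agent that is not named here (on this read-out lower numbers stand for stronger inhibition and higher numbers for weaker inhibition), compound 1 returns only the assay limit, > 50000 nM. Compound 2 `C=C1CC[C@H]2[C@@](C)(CC[C@@H](OC(=O)c3cccnc3)[C@@]2(C)NC=O)[C@@H]1/C=C/C1=CCOC1=O` carries the (pyridin-3-yl)carbonyl ester. In this assay compound 2 likewise returns only the limit, > 50000 nM. Going by the values given here, compound 2 therefore stands at the limit of > 50000 nM in this assay, at which 2 of the 2 values shown sit, and no numerical step between measured compounds can be drawn from these two values. Compound 3 `C=C1CC[C@H]2[C@@](C)(CC[C@@H](OC(=O)CN)[C@@]2(C)NC=O)[C@@H]1/C=C/C1=CCOC1=O` is not yet measured; it differs from compound 2 by aminomethyl in place of pyridin-3-yl on a carbonyl carbon. With both measured values at the limit, nothing in the series argues for a change beyond the scatter, and the step expected for this assay, a step that the limit leaves unreadable from compound 2 to compound 3, is essentially none. Compound 3 is accordingly estimated at 60000 nM, within 20000 nM to 200000 nM, with a good chance that only a limit is again reported.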

Compound 3, half-maximal inhibitory concentration: > 50000 nM
Compound 3 was reported as a limit (the forecaster's own chance of this, stated with the estimate: 85%); the middle value lies beyond the limit too.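

No step can be read from compound 2 to compound 3, as both return only a limit in this assay, and the series stands at one value: the limit of > 50000 nM in this assay, at which 3 of the 3 values shown sit.

The compounds shown leave open whether any change on the shared core gives a measurable inhibition, and how pyridin-3-yl and aminomethyl compare on that carbonyl carbon.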